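A few compounds are considered here, and "the series" means these few. Any claim that something is new, unique, unknown or untested is made for them only; others in the source may bear on it.

Measured compounds:
Compound 1, `C/C(=N\NC(=O)CC#N)c1ccc(NS(=O)(=O)c2ccc(Cl)cc2)cc1`, gives 8000 nM.
Compound 2, `C/C(=N\NC(=O)C(C#N)C(=S)S)c1ccc(NS(=O)(=O)c2ccc(Cl)cc2)cc1`, gives 17500 nM.
Compound 3, `CCOC(=O)c1c(/C=C/c2ccccc2)c(C#N)c(=O)n(/N=C(\C)c2ccc(NS(=O)(=O)c3ccc(Cl)cc3)cc2)c1N`, gives 10700 nM.

In a functional assay on HepG2 cells (Homo sapiens) for cytotoxicity, read by sulforhodamine B assay, with a stated time of 48 h (on this read-out higher numbers stand for weaker inhibition and lower numbers for stronger inhibition), compound 3 stands second highest of the three numbers, and its gaps to compound 1 and to compound 2 both lie within the scatter. Compound 4, `CCOC(=O)c1c(-c2ccc([N+](=O)[O-])cc2)c(C#N)c(=O)n(/N=C(\C)c2ccc(NS(=O)(=O)c3ccc(Cl)cc3)cc2)c1N`, differs from compound 3 by 4-nitrophenyl in place of 2-phenylethenyl on an aromatic carbon. Within the data shown here, the only measured step, a 2.2-fold higher number from compound 1 to compound 2 (0.34 log units; beyond the scatter), concerns a different place on a different core, so it carries no direct lesson for this exchange of one aryl group for another. Among the measured compounds shown here, with no step that bears on it, the expectation is a change no larger than the scatter, estimated as a 1.1-fold lower number from compound 3 to compound 4 (0.03 log units; within the scatter). Compound 4 is therefore expected to give 10000 nM, within a range from 4000 nM to 25000 nM.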

Compound 4, half-maximal inhibitory concentration: 41100 nM
Compound 4: middle estimate off by 4.1-fold (0.61 log units), on the low side; the whole stated range lies below it.
By their numbers in this assay, from the lowest: compounds 1, 3 and 2 (each within the scatter of the next, the first and the last beyond it); then compound 4.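

In this assay, this position, opposite the ring nitrogen, proves sensitive to the group it carries: 4-nitrophenyl in place of 2-phenylethenyl gives a 3.8-fold higher number from compound 3 to compound 4 (0.58 log units; beyond the scatter), which means weaker inhibition. Among these compounds, the earlier compounds held no step at this place, so this is the first sign that the choice of group here matters. Nothing available explains the rise. The change swaps the whole group at once, so the nitro group and the loss of the 2-phenylethenyl chain cannot be told apart. Plain phenyl at this position would separate the two.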